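Dithiolane amides and their ring-opened dithiols on KB cells

This account rests on a few compounds, and the source may have more. Where it says the series, first, only, none or still open, it means among the compounds named here.

Measured so far:
compound 1, `O=C(CCCCC1CCSS1)Nc1ccc(Cl)cn1`: 28.6%
compound 2, `O=C(CCCCC1CCSS1)Nc1cccc2ccccc12`: "not active" (no number reported)
compound 3, `O=C(CCCCC(S)CCS)Nc1ccc(Cl)cn1`: 21.6%

In a functional assay on KB cells (Homo sapiens) for inhibition, read by MTT assay, with a stated time of 24 h, tested at 10 ug/mL (a higher number here means more inhibition of growth at the concentration tested, a lower number less inhibition of growth), compound 1 gives 28.6%, while compound 2 is reported as "not active" (no number reported), with no number given. The cores of compound 1 and compound 2 differ in more than one place, and the difference between the two cores is not broken down here. Opening the ring gives compound 3, which in this assay gives 21.6%. This change, (a group of 5 heavy atoms (3 carbon, 2 sulfur; no ring) in place of a group of 5 heavy atoms (3 carbon, 2 sulfur; one five-membered non-aromatic ring with 2 hetero atoms), on a saturated chain carbon, four bonds along the chain from a carbonyl carbon), produced a number 7 percentage points lower from compound 1 to compound 3 (within the scatter). The same kind of change on compound 2 gives the unmeasured compound 4, `O=C(CCCCC(S)CCS)Nc1cccc2ccccc12`, as a group of 5 heavy atoms (3 carbon, 2 sulfur; no ring) in place of a group of 5 heavy atoms (3 carbon, 2 sulfur; one five-membered non-aromatic ring with 2 hetero atoms), on a saturated chain carbon, four bonds along the chain from a carbonyl carbon. Since the ring-opening on compound 1 moved nothing beyond the scatter, as a number 7 percentage points lower from compound 1 to compound 3 (within the scatter) shows, compound 4 is expected to stay near compound 2, which shows no activity. Compound 4 is estimated at 8% in this assay, between 0% and 22%.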

Compound 4, percent growth inhibition at one concentration: "not active" (no number reported)
The entry for compound 4 holds no number; no gap can be computed for the estimate.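

Compound 2 and compound 4 both stand without a number, so no step can be read between them. As far as these compounds go, whether opening the ring shifts growth inhibition on this core stays open. No evidence bears on this result.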